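Replacing a methoxy with chloro in compound 2

This account rests on a few compounds, and the source may have more. Where it says the series, first, only, none or still open, it means among the compounds named here.

Compound 1 `C=C(c1ccc(OC)cc1)c1cc(OC)c(OC)c(OC)c1-c1ccc(OC)cc1`: 72000 nM
Compound 2 `C=C(c1ccc(OC)cc1)c1cc(OC)c(OC)c(OC)c1-c1ccccc1`: 11000 nM

In a functional assay on HeLa cells (Homo sapiens) for cytotoxicity, read by MTT assay, with a stated time of 48 h (on this read-out lower numbers stand for stronger inhibition and higher numbers for weaker inhibition), compound 2 has the lower of the two numbers, so it shows the stronger inhibition. Compound 3 `C=C(c1ccc(Cl)cc1)c1cc(OC)c(OC)c(OC)c1-c1ccccc1` places chloro where compound 2 has a methoxy, para to a large group: chloro in place of methoxy on an aromatic carbon. Going by the values given here, only one measured step bears on this change. That step, a 6.5-fold lower number from compound 1 to compound 2 (0.82 log units; beyond the scatter), replaced a different methoxy with hydrogen and was modest. Only a small shift toward a lower number is therefore expected, and it may stay within the scatter. The expected step is a 1.4-fold lower number from compound 2 to compound 3 (0.14 log units; within the scatter). For compound 3, the estimated value is 8000 nM, with an expected range of 2500 nM to 25000 nM.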

Compound 3, half-maximal inhibitory concentration: 34000 nM
For compound 3 the middle estimate is 4.3-fold (0.63 log units) below the measured one; measured number outside the range, above it.
By their numbers in this assay, from the lowest: compound 2; then compound 3; then compound 1.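

In this assay, the change from 4-methoxyphenyl to 4-chlorophenyl gives a 3.1-fold higher number from compound 2 to compound 3 (0.49 log units; beyond the scatter), so the group at this position affects the result. The earlier step removed a different methoxy and lowered the number, whereas replacing this methoxy with chloro raises it, so these two places on the molecule do not respond alike. Nothing measured here explains the rise. The compounds shown leave open whether the methoxy of compound 2 helps or the chloro of compound 3 hurts. A hydrogen, a fluoro or an amine at this position could help separate the two.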